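The compounds below may be only part of what the source reports. "The series", "measured", "known", "first", "only" and "open" are said of these compounds alone.

Compound 3 `CCC(CC)(c1ccc(OCCCCCCO)c(C)c1)c1ccc(OCC(O)C(C)(C)C)c(OCC(O)C(C)(C)C)c1` stands highest of the three compounds in an assay on cells for binding affinity to vitamin D3 receptor (Homo sapiens), read by fluorescence, tested at 1 uM (a lower number here means less inhibition, a higher number more inhibition at the concentration tested (going by the name of the read-out)), where compound 3 gives 52%. Compound 2 `CCC(CC)(c1ccc(OCCO)c(C)c1)c1ccc(OCC(O)C(C)(C)C)c(OCC(O)C(C)(C)C)c1` gives 38% and compound 1 `CCC(CC)(c1ccc(OS(=O)(=O)c2ccc(C)cc2)c(C)c1)c1ccc(OCC(=O)C(C)(C)C)c(OCC(=O)C(C)(C)C)c1` gives 35% in this assay. Among the measured compounds shown here, the one measured step, a number 14 percentage points higher from compound 2 to compound 3 (beyond the scatter), concerns the length of the chain that carries the hydroxy, not the group at its end. Compound 4 `CCC(CC)(c1ccc(OCCCCCCC(=O)O)c(C)c1)c1ccc(OCC(O)C(C)(C)C)c(OCC(O)C(C)(C)C)c1` differs from compound 3 by carboxy in place of hydroxy on a saturated chain carbon, six bonds along the chain from an oxygen on an aromatic ring. For the measured compounds named here, no measured step bears on this exchange of hydroxy for carboxy, so the expectation for compound 4 rests only on the closeness of its structure to compound 3 and is estimated as a number 2 percentage points lower from compound 3 to compound 4 (within the scatter), a step not expected to go beyond the scatter. Compound 4 is therefore estimated at 50%, in a range from 30% to 70%.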

Compound 4, a percentage reported as inhibition, at one concentration (the size of the read-out at that concentration, not a potency): "not active" (no number reported)
No number was reported for compound 4; no gap can be computed for the estimate.
By their numbers in this assay, from the lowest: compounds 1 and 2 (each within the scatter of the next); then compound 3.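

Compound 4 is reported as not active in this assay without a number, so no step from compound 3 can be read, and no evidence shown bears on this result. The compounds shown leave open how carboxy would read on a shorter chain.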